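Working notes: the step from compound 1 to compound 3

A few compounds are considered here, and "the series" means these few. Any claim that something is new, unique, unknown or untested is made for them only; others in the source may bear on it.

- compound 1 `OC[C@H]1O[C@H](n2cc(-c3ccccc3)nn2)[C@@H](O)[C@@H](O)[C@@H]1O`: > 3000 ug/mL
- compound 2 `OC[C@H]1O[C@H](n2cc(-c3cccc(Cl)c3)nn2)[C@@H](O)[C@@H](O)[C@@H]1O`: 705 ug/mL
- compound 3 `OC[C@H]1O[C@H](n2cc(-c3ccc(C(F)(F)F)cc3)nn2)[C@@H](O)[C@@H](O)[C@@H]1O`: not yet measured

In a physicochemical assay for solubility, read by LC-MS, using the shake flask method, measured as thermodynamic solubility, with a stated time of 24 h, at pH 6.5 (a higher number here means a more soluble compound, a lower number a less soluble compound), compound 1 stands at > 3000 ug/mL, which is a limit and not a number. Compound 3 carries trifluoromethyl in place of hydrogen on an aromatic carbon. Among the measured compounds shown here, the one measured step bearing on this is an at least 4.2-fold lower number from compound 1 to compound 2 (0.62 log units; beyond the scatter), with chloro in place of hydrogen on an aromatic carbon. From that step alone, a move to a lower number beyond the scatter is expected in this assay, of similar or somewhat larger size. The expected step is an at least 8.5-fold lower number from compound 1 to compound 3 (0.93 log units; beyond the scatter). For compound 3 the estimated value is 350 ug/mL, with an expected range of 100 ug/mL to 1000 ug/mL.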

Compound 3, solubility: 159 ug/mL
For compound 3 the middle estimate is 2.2-fold (0.34 log units) above the measured one, within the range that was stated.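

In this assay, trifluoromethyl in place of hydrogen on an aromatic carbon, para to a large group, gives an at least 18-fold lower number from compound 1 to compound 3 (1.27 log units; beyond the scatter). A second replacement of hydrogen on this ring therefore also lowers the number beyond the scatter, here in a step printed as large rather than at least modest. Compound 1 stands at a limit, so the full size of this step cannot be read: the limit of > 3000 ug/mL in this assay, at which 1 of the 3 values shown sits.

Compound 2 and compound 3 differ in both the group and its place, and the effects of the two remain unseparated. As far as these compounds go, whether an amine or a carboxylic acid on this carbon would move the number the same way remains open.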